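A few compounds are considered here, and "the series" means these few. Any claim that something is new, unique, unknown or untested is made for them only; others in the source may bear on it.

Measured in an ADME assay on TZM cells (Homo sapiens) for cytotoxicity, read by XTT assay, with a stated time of 4 days; a higher number here means that more compound is tolerated, a lower number that less compound is tolerated:
- Compound 1 `Cc1cc(CCC#N)cc(C)c1Oc1cc(Nc2ccc(C#N)cc2)c(N)cc1C(=O)O`: 14300 nM
- Compound 2 `Cc1cc(N)cc(C)c1Oc1cc(Nc2ccc(C#N)cc2)c(N)cc1C(F)(F)F`: 15800 nM
- Compound 3 `CNC(=O)c1cc2ncn(-c3ccc(C#N)cc3)c2cc1Oc1c(C)cc(CCC#N)cc1C`: > 890000 nM (a limit of the assay)

Compound 2, at 15800 nM, has compound 1 as its nearest neighbour at 14300 nM, and these two values lie within the scatter of each other. Compound 3 gives only a limit of the assay, not a number, and so does not place compound 2 any more closely.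

The next entry is compound 4 `CC(=O)CCc1cc(C)c(Oc2cc(Nc3ccc(C#N)cc3)c(N)cc2C(F)(F)F)c(C)c1`. It carries 2-acetylethyl in place of amino on an aromatic carbon, meta to two methyl groups and para to a large group: 2-acetylethyl in place of amino on an aromatic carbon.

Among the measured compounds shown here, no measured pair in this set isolates a change of this kind, so the size of the step in this assay cannot be read directly from the data. The expectation therefore stays close to compound 2 at 15800 nM, with no clear direction and no shift beyond the scatter. The estimated change is a 1.3-fold lower number from compound 2 to compound 4 (0.12 log units; within the scatter), which is expected to remain within the scatter. For compound 4 the expected value is 12000 nM, with an estimated range of 4000 nM to 35000 nM.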

Compound 4, half-maximal cytotoxic concentration: 11100 nM
Beside the measured number, compound 4's estimate is 1.1-fold (0.03 log units) above it; the measured number falls inside the stated range.
By their numbers in this assay, from the lowest: compounds 4, 1 and 2 (each within the scatter of the next). At a limit, above all of these: compound 3.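

In this assay, the aromatic carbon meta to two methyl groups and para to a large group now has its first direct reading, with 2-acetylethyl in place of amino: a 1.4-fold lower number from compound 2 to compound 4 (0.15 log units; within the scatter). Amino, with 1 heavy atom and 1 hydrogen-bond donor, leaves; 2-acetylethyl, with 5 heavy atoms and 0 hydrogen-bond donors, enters; and the two compounds stay within the scatter of each other. Among the compounds shown here, compounds 1, 2 and 3 could not show this, since no pair among them differs in one place, whereas this single step shows that, in this read-out, the larger chain and amino are not told apart at this position.

As far as these compounds go, whether a carboxylic acid, a primary amine at the end of a longer chain or a hydroxyl group at this position would also stay within the scatter remains open, as one step gives no trend across groups. Compound 3 stands only as a limit of the assay, and no single change connects it to the other compounds: the limit of > 890000 nM in this assay, at which 1 of the 4 values shown sits.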